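From hydroxy to bromo at one aromatic carbon

The source may report more compounds than this note shows. Statements on the series, on what has been measured and on what is new or still open speak of the compounds shown alone.

Compound 1 (`COc1ccc(C2=C(c3cc(OC)c(OC)c(OC)c3)CC3CCCN3C2=O)cc1O`) gives > 100000 nM as a limit of the assay.
Compound 2 (`COc1ccc(C2=C(c3ccc(SC)cc3)CC3CCCN3C2=O)cc1O`) gives 20000 nM as a measured number.
Compound 3 (`COc1ccc(C2=C(c3ccc(SC)cc3)CC3CCCN3C2=O)cc1OC(=O)C1CCCN1C(=O)OC(C)(C)C`) gives 10000 nM as a measured number.

In a functional assay on SW-620 cells (Homo sapiens) for cytotoxicity (on this read-out lower numbers stand for stronger inhibition of growth and higher numbers for weaker inhibition of growth), compound 2 gives 20000 nM and compound 3 gives 10000 nM and these two numbers lie within the scatter of each other. Compound 1 is known only through a limit.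

Compound 4 (`COc1ccc(C2=C(c3ccc(SC)cc3)CC3CCCN3C2=O)cc1Br`) departs from compound 2 by bromo in place of hydroxy on an aromatic carbon in a single place, with bromo in place of hydroxy on an aromatic carbon, ortho to a methoxy group. Among the compounds with values here, no two measured compounds differ in one place alone, so no direct step guides the expectation. The estimated step of a 1.3-fold lower number from compound 2 to compound 4 (0.12 log units; within the scatter) is expected to stay within the scatter in this assay and to show no clear direction. For compound 4 the estimated value is 15000 nM with an expected range from 4000 nM to 60000 nM around that estimate.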

Compound 4, concentration for 50% growth inhibition: 5000 nM
The estimate for compound 4 lay 3.0-fold (0.48 log units) above the measured number; the measured number falls inside the stated range.
By their numbers in this assay, from the lowest: compounds 4, 3 and 2 (each within the scatter of the next, the first and the last beyond it). At a limit, above all of these: compound 1.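

In this assay, within the data shown here, bromo in place of hydroxy on this aromatic carbon, ortho to a methoxy group, gives a 4.0-fold lower number from compound 2 to compound 4 (0.60 log units; beyond the scatter), the first single-place change here whose size can be read. It shows that growth inhibition at this position does not depend on keeping the hydroxy: the group that enters has no hydrogen-bond donor or acceptor, and the number falls rather than rises. Compound 1 stays outside this comparison, as it differs in more than one place and its value is only a limit: the limit of > 100000 nM in this assay, at which 1 of the 4 values shown sits.

From the compounds shown here alone, whether a chloro, a methyl or an amine at this carbon would read like bromo remains open. Also open, going by these compounds, is whether the same change would have a similar effect on the core of compound 1.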